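Toxicity series: amide variations on a shared core

This account rests on a few compounds, and the source may have more. Where it says the series, first, only, none or still open, it means among the compounds named here.

Compound 3 `COc1ccc(C(=O)Nc2ncc(-c3ccc(OC)cc3)n2C)cc1` is measured in a toxicity assay on THP-1 cells (Homo sapiens) for inhibition (on this read-out higher numbers stand for lower toxicity in this test and lower numbers for higher toxicity in this test), only as a limit, giving > 100000 nM. Compound 1 `COc1ccc(-c2cnc(NC(=O)c3cccc(OC)c3)n2C)cc1` likewise reaches only the limit, with > 100000 nM in this assay. Compound 2 `COc1ccc(-c2cnc(NC(=O)c3cccnc3)n2C)cc1` also stops at the limit, at > 100000 nM in this assay. All three values sit on one line, (the limit of > 100000 nM in this assay, at which 3 of the 3 values shown sit), so the steps a step that the two limits leave unreadable from compound 1 to compound 2, a step that the two limits leave unreadable from compound 1 to compound 3 and a step that the two limits leave unreadable from compound 2 to compound 3 cannot be read in size.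

Compound 4 `COc1ccc(-c2cnc(NC(=O)c3cccc(Br)c3)n2C)cc1` is not yet measured. Its change from compound 3 is 3-bromophenyl in place of 4-methoxyphenyl on a carbonyl carbon. Among the compounds with values here, no measured step is readable, so no direction beyond the scatter is expected; the step that the limit leaves unreadable from compound 3 to compound 4 is expected to stay at the limit. Compound 4 is estimated at 150000 nM, within 40000 nM to 600000 nM.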

Compound 4, half-maximal cytotoxic concentration: > 100000 nM
Compound 4 gave a limit, no number; the forecaster's own chance of this, stated with the estimate: 75%; the middle value is on the limit's open side.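

Compound 4 sits at the same limit as compound 1, compound 2 and compound 3 in this assay, so no step among them can be read: the limit of > 100000 nM in this assay, at which 4 of the 4 values shown sit.

The compounds shown leave open whether any amide variation on the shared core gives a value short of this limit.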